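Cytotoxicity of a thienopyrimidine series on cultured cells

A few compounds are considered here, and "the series" means these few. Any claim that something is new, unique, unknown or untested is made for them only; others in the source may bear on it.

Measured so far:
compound 1 `Cc1cc(/C=C/C#N)cc(C)c1Oc1nc(Nc2ccc(CN3CCN(S(C)(=O)=O)CC3)cc2)nc2ccsc12`: 20700 nM
compound 2 `Cc1cc(/C=C/C#N)cc(C)c1Oc1nc(Nc2ccc(CN3CCNCC3)cc2)nc2ccsc12`: 3970 nM
compound 3 `Cc1cc(/C=C/C#N)cc(C)c1Oc1nc(Nc2ccc(CN3CCNCC3)cc2)nc2sccc12`: 4030 nM

In an ADME assay on MT4 cells (Homo sapiens) for cytotoxicity, read by MTT assay, with a stated time of 5 days (on this read-out lower numbers stand for higher toxicity in this test and higher numbers for lower toxicity in this test), compound 3 gives 4030 nM, the second highest of the three numbers. Compound 2 gives 3970 nM, and the two values lie within the usual scatter of each other, so no order between them is claimed. Compound 1 gives 20700 nM, and the step from compound 3 to compound 1 lies beyond the scatter.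

Compound 4 `Cc1cc(/C=C/C#N)cc(C)c1Oc1nc(Nc2ccc(N3CCN(S(C)(=O)=O)CC3)cc2)nc2sccc12` is not yet measured. It differs from compound 3 by 4-(methylsulfonyl)piperazin-1-yl in place of (piperazin-1-yl)methyl on an aromatic carbon. For the measured compounds named here, the single comparable step on record is a 5.2-fold lower number from compound 1 to compound 2 (0.72 log units; beyond the scatter), which runs in the opposite direction: there the methylsulfonyl group left the ring nitrogen. Going by the values given here, compound 4 adds that group back, while also losing the methylene linker, for which no measured pair gives guidance. The account therefore expects the number for compound 4 to rise beyond the scatter, by about a 4.5-fold higher number from compound 3 to compound 4 (0.65 log units; beyond the scatter). The estimate for compound 4 in this assay is 18000 nM, with a range from 6000 nM to 50000 nM.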

Compound 4, half-maximal cytotoxic concentration: > 222000 nM
Compound 4 was reported as a limit; the forecaster's own chance of this, stated with the estimate: 10%; middle value at least 12-fold (1.09 log units) away from the limit.
By their numbers in this assay, from the lowest: compounds 2 and 3 (each within the scatter of the next); then compound 1. At a limit, above all of these: compound 4.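

At this place, on an aromatic carbon of the six-membered ring of carbon only, the change gives an at least 55-fold higher number from compound 3 to compound 4 (1.74 log units; beyond the scatter) in this assay. The earlier compounds had shown only the methylsulfonyl group alone leaving the ring nitrogen, with a 5.2-fold lower number from compound 1 to compound 2 (0.72 log units; beyond the scatter), whereas this change brings that group in and also removes the methylene linker, and its printed step is the larger of the two. Compound 4 stands at a limit of the assay, so its step has a lower bound and no exact size: the limit of > 222000 nM in this assay, at which 1 of the 4 values shown sits.

The compounds shown do not separate the share of the methylsulfonyl group from that of the methylene linker in this step. As far as these compounds go, whether an acetyl or a plain methyl group on the same ring nitrogen, or a morpholine ring in place of the piperazine, would move the number the same way also stays open.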